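The source may report more compounds than this note shows. Statements on the series, on what has been measured and on what is new or still open speak of the compounds shown alone.

In a functional assay on MT4 cells (Homo sapiens) for cytotoxicity, read by MTT assay (a lower number here means that less compound is tolerated, a higher number that more compound is tolerated), compound 1 `Cc1c(O)nc(SCc2ccc(C#N)cc2)nc1Cc1c(Cl)cccc1Cl` gives > 60000 nM, which is a limit and not a number. Compound 2 `COc1cc(CSc2nc(O)c(C)c(Cc3c(F)cccc3F)n2)cc(OC)c1` gives > 60000 nM, also a limit. Compound 3 `Cc1c(O)nc(SCc2ccc(C#N)cc2)nc1Cc1c(F)cccc1F` gives > 65000 nM, again a limit. Compound 1 therefore has no exact position in the series and sits with one other value at the limit of > 60000 nM in this assay, at which 2 of the 3 values shown sit. The remaining value sits at the limit of > 65000 nM in this assay, at which 1 of the 3 values shown sits.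

Compound 4 `Cc1c(O)nc(SCc2ccc(Br)cc2)nc1Cc1c(Cl)cccc1Cl` keeps the rest of compound 1 but has bromo in place of cyano on an aromatic carbon, para to a large group, turning 4-cyanobenzyl into 4-bromobenzyl: bromo in place of cyano on an aromatic carbon. Among the compounds with values here, the only measured step between closely matched compounds is a step that the two limits leave unreadable from compound 1 to compound 3. It exchanges 2,6-dichlorophenyl for 2,6-difluorophenyl, leaves the cyano untouched and gives no size to carry over. Within the data shown here, no measured step covers the exchange of cyano for bromo, so the expectation rests on the limit of compound 1 and on the absence of any exact value in this assay. A step beyond the scatter is not firmly expected, though any shift is expected to lean towards less compound being tolerated. The expected step, which is only an estimate, is an at least 1.2-fold lower number from compound 1 to compound 4 (0.07 log units; that floor lies within the scatter). Compound 4 may also read only as a limit. For compound 4 the estimated value is 50000 nM, with an expected range from 15000 nM to 90000 nM.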

Compound 4, half-maximal cytotoxic concentration: 13000 nM
For compound 4 the middle estimate is 3.8-fold (0.59 log units) above the measured one; the measured number lies below the stated range.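

In this assay compound 4, with its 4-bromobenzyl, gives 13000 nM, the only exact value among the compounds shown. Within the data shown here, the exchange of cyano for bromo produces an at least 4.6-fold lower number from compound 1 to compound 4 (0.66 log units; beyond the scatter), so this aromatic carbon is a place where the tolerated concentration can move, which the earlier compounds, all standing at limits, could not show. Compound 1 gives > 60000 nM, which is a limit, so the step has a floor and no readable upper size: the limit of > 60000 nM in this assay, at which 2 of the 4 values shown sit.

Among these compounds, the one earlier step between matched compounds cannot be read, both of its ends being limits, so it remains open whether bromo would lower the number in the same way with 2,6-difluorophenyl in place of 2,6-dichlorophenyl. Going by these compounds, it also remains open whether the shift follows the entry of bromo or the loss of cyano, and how an amine or a carboxylic acid on this same aromatic carbon would read in this assay.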